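The source may hold more compounds than are shown below. What is called first, only, known or untested is meant among the compounds shown, and "the series" means these compounds.

Measured so far:
- compound 2, `Nc1ccccc1NC(=O)c1ccc(CSc2cccc(F)c2)cc1`: 2870 nM
- compound 1, `CCc1ccc(SCc2ccc(/C=C/C(=O)Nc3ccccc3N)cc2)cc1`: "not determined" (no result reported)
- compound 3, `Nc1ccccc1NC(=O)/C=C/c1ccc(CSc2ccc(F)cc2)cc1`: "not determined" (no result reported)

Going by the values given here, compound 2 carries the only number in this set. In a functional assay on HCT-116 cells (Homo sapiens) for antiproliferative activity, read by CCK-8 assay, with a stated time of 72 h (on this read-out lower numbers stand for stronger inhibition and higher numbers for weaker inhibition), compound 2 gives 2870 nM; compound 1 and compound 3 bring no value, so compound 2 cannot be ranked against anything and simply marks the single reference point of the series.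

Compound 4, `Nc1ccccc1NC(=O)c1ccc(CSc2ccc(Cl)cc2)cc1`, has not been measured. It differs from compound 2 in one place: 4-chlorophenyl in place of 3-fluorophenyl on a sulfur. Among the compounds with values here, no step between two measured compounds is available to calibrate this change, so there is nothing in the data that fixes its direction or size; the expectation below rests on the single value of compound 2 alone.

Within the data shown here, with no comparable step to lean on, the step from compound 2 to compound 4 is expected to stay within the usual scatter of repeated measurements, with no clear direction; the estimated step is a 1.2-fold lower number from compound 2 to compound 4 (0.10 log units; within the scatter). For compound 4 the expected value in this assay is 2300 nM, with a range from 900 nM to 6000 nM, taken wide because only one measured anchor exists.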

Compound 4, half-maximal inhibitory concentration: 3750 nM
For compound 4 the middle estimate is 1.6-fold (0.21 log units) below the measured one; low and high end bracket the measured number.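

In this assay, going by these compounds alone, 4-chlorophenyl in place of 3-fluorophenyl on a sulfur gives a 1.3-fold higher number from compound 2 to compound 4 (0.12 log units; within the scatter), the first step that can be read at this position. Within the series, this position therefore accepts a simultaneous exchange of the halogen and of the substitution pattern on the phenyl ring without a change that stands out from the scatter, and the two values give no order between the two compounds. Nothing available explains this result or bears on it.

Steps involving compound 1 and compound 3 cannot be read, so the compounds shown do not tell whether the same exchange would behave alike in the core of compound 1, or how that core compares with the one shared by compound 2 and compound 4. As far as these compounds go, it also remains open how far this tolerance extends, for example to an amine or a carboxylic acid on the phenyl ring, or to a longer chain in place of the ring, since one step between two halogen-bearing phenyl groups says nothing about such groups.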